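Benzyl-triazole amides: cytotoxicity step to the nitro analogue

A few compounds are considered here, and "the series" means these few. Any claim that something is new, unique, unknown or untested is made for them only; others in the source may bear on it.

Compound 1 `CCOC(=O)Cn1cc(CNC(=O)c2cnc(Nc3ccc(C#N)cc3)cc2Oc2c(C)cc(C)cc2C)nn1` carries ethoxycarbonyl on the saturated chain carbon bound to the aromatic nitrogen of the triazole; in an ADME assay on MT4 cells (Homo sapiens) for cytotoxicity, read by MTT assay, with a stated time of 5 days (a higher number here means that more compound is tolerated, a lower number that less compound is tolerated), compound 1 gives 9530 nM. Compound 2 `Cc1cc(C)c(Oc2cc(Nc3ccc(C#N)cc3)ncc2C(=O)NCc2cn(Cc3cccc(Cl)c3)nn2)c(C)c1` gives 187000 nM in this assay. Compound 3 `Cc1cc(C)c(Oc2cc(Nc3ccc(C#N)cc3)ncc2C(=O)NCc2cn(Cc3cccc(F)c3)nn2)c(C)c1` reaches only a limit of this assay, >= 204000 nM, and no number. Compound 3 therefore sits at the limit of >= 204000 nM in this assay, at which 1 of the 3 values shown sits, and the step of an at least 21-fold higher number from compound 1 to compound 3 (1.33 log units; beyond the scatter) is large, as is a 20-fold higher number from compound 1 to compound 2 (1.29 log units; beyond the scatter); the halogen swap an at least 1.0-fold higher number from compound 2 to compound 3 (0.03 log units; that floor lies within the scatter) stays within scatter.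

Compound 4 `Cc1cc(C)c(Oc2cc(Nc3ccc(C#N)cc3)ncc2C(=O)NCc2cn(Cc3ccc([N+](=O)[O-])cc3)nn2)c(C)c1` differs from compound 3 by 4-nitrophenyl in place of 3-fluorophenyl on a saturated chain carbon bound to an aromatic nitrogen. Going by the values given here, no measured step changes a substituent on that phenyl ring beyond the halogen swap, which showed no movement; both aryl-bearing compounds 2 and 3 sit far above compound 1. A nitro-bearing aryl in the same place is therefore expected to remain in the high range, most likely near or at the limit, with the step of an at least 1.3-fold lower number from compound 3 to compound 4 (0.13 log units; that floor lies within the scatter) expected to be small. For compound 4 the estimate in this assay is 150000 nM, with a range from 45000 nM to 250000 nM.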

Compound 4, half-maximal cytotoxic concentration: >= 139000 nM
Compound 4: no number, only a limit (the forecaster's own chance of this, stated with the estimate: 50%); the middle value is on the limit's open side.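

In this assay compound 4 also reaches only a limit: the limit of >= 139000 nM in this assay, at which 1 of the 4 values shown sits.

With 4-nitrophenyl in place of ethoxycarbonyl, the result is an at least 14-fold higher number from compound 1 to compound 4 (1.16 log units; beyond the scatter), so the large step at this saturated chain carbon bound to an aromatic nitrogen is no longer confined to the halogen-bearing rings of compound 2 and compound 3. The steps from compound 2 and from compound 3 to compound 4 cannot be read, so the three aryl-bearing compounds cannot be ordered.

Going by these compounds, it remains open whether the step depends on the phenyl ring or simply on the absence of ethoxycarbonyl. A carboxylic acid or a longer alkyl chain at this place, or an amine on the ring, would test how far this tolerance extends.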